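Aryl change on the amide-type nitrogen: working notes

The compounds below may be only part of what the source reports. "The series", "measured", "known", "first", "only" and "open" are said of these compounds alone.

Compound 1 `CSc1cccc(N2C(=O)CN(c3ccccc3)CC2C(=O)NC2CCCC2)c1` gives > 50000 nM as a limit
Compound 2 `CSc1cccc(N2C(=O)CN(c3cc(C(F)(F)F)ccc3C)CC2C(=O)NC2CCCC2)c1` gives 10000 nM as a number
Compound 3 `CSc1cccc(N2C(=O)CN(c3cncc(C(F)(F)F)c3)CC2C(=O)NC2CCCC2)c1` gives > 50000 nM as a limit

In an ADME assay on HepG2 cells (Homo sapiens) for cytotoxicity (on this read-out lower numbers stand for higher toxicity in this test and higher numbers for lower toxicity in this test), compound 1 gives > 50000 nM which is a limit and not a number. It shares that position with compound 3: the limit of > 50000 nM in this assay, at which 2 of the 3 values shown sit.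

Compound 4 `O=C(NC1CCCC1)C1CN(c2ccccc2)CC(=O)N1c1ccc2ccsc2c1` is the next to be read. It differs from compound 1 on an amide-type nitrogen in a ring, with 1-benzothiophen-6-yl in place of 3-(methylsulfanyl)phenyl on an amide-type nitrogen in a ring.

Among the compounds with values here, no measured step touches this place, so the evidence is indirect. All three steps change the aryl group on the amine nitrogen in a ring. One change gave an at least 5.0-fold lower number from compound 1 to compound 2 (0.69 log units; beyond the scatter) and another gave an at least 5.0-fold higher number from compound 2 to compound 3 (0.69 log units; beyond the scatter) while the third gave a step that the two limits leave unreadable from compound 1 to compound 3 for its reading. In this assay, within the data shown here, the only number so far belongs to compound 2 at 10000 nM and it came from a change at that other place. A step beyond the scatter is therefore not expected with any confidence, though a modest move to a lower number remains possible, and another limit is quite likely.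

The expected change is an at least 1.2-fold lower number from compound 1 to compound 4 (0.09 log units; that floor lies within the scatter) as an estimate. For compound 4 the estimated value is 40000 nM with an expected range from 15000 nM to 80000 nM in this reading.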

Compound 4, half-maximal cytotoxic concentration: > 50000 nM
Compound 4: no number, only a limit (the forecaster's own chance of this, stated with the estimate: 55%); middle value at least 1.2-fold (0.09 log units) away from the limit.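

In this assay compound 4 gives > 50000 nM, which is a limit and not a number. Compound 1 also stands at a limit, so no step from compound 1 to compound 4 can be read: the limit of > 50000 nM in this assay, at which 3 of the 4 values shown sit.

The compounds shown leave open how 1-benzothiophen-6-yl compares with 3-(methylsulfanyl)phenyl on the amide-type nitrogen in this read-out.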